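The source may report more compounds than this note shows. Statements on the series, on what has been measured and on what is new or still open speak of the compounds shown alone.

The compounds measured so far, each in a functional assay on MCF7 cells (Homo sapiens) for cytotoxicity, read by sulforhodamine B assay, with a stated time of 48 h; on this read-out lower numbers stand for higher toxicity in this test and higher numbers for lower toxicity in this test:

Compound 1, `COc1cc(/C(Cl)=C/C=C(\C#N)C(=O)c2c[nH]c3ccccc23)cc(OC)c1OC` — a limit of the assay, > 100000 nM
Compound 2, `COc1ccc(/C(Cl)=C/C=C(\C#N)C(=O)c2c[nH]c3ccccc23)cc1OC` — a limit of the assay, > 100000 nM
Compound 3, `COc1cc(/C(Cl)=C/C=C(\C#N)C(=O)c2c(C)[nH]c3ccccc23)cc(OC)c1OC` — a limit of the assay, > 100000 nM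

Compound 1 therefore has no number in this assay, only a limit. The same holds for compound 2 and for compound 3, so that all three values sit at the limit of > 100000 nM in this assay, at which 3 of the 3 values shown sit, and none of them can be put in order against another.

Compound 4, `COc1ccc2[nH]cc(C(=O)/C(C#N)=C/C=C(\Cl)c3cc(OC)c(OC)c(OC)c3)c2c1`, has not yet been measured in this assay. It differs from compound 1 in one place: methoxy in place of hydrogen on an aromatic carbon.

Two measured steps start from compound 1, and both touch the structure at a different site from the change that leads to compound 4. The step from compound 1 to compound 2 is a step that the two limits leave unreadable from compound 1 to compound 2, and the step from compound 1 to compound 3 is a step that the two limits leave unreadable from compound 1 to compound 3. Neither gives a size, so neither shows whether any single change on the core of compound 1 moves the read-out away from the limit.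

With nothing in the measured steps to point either way, compound 4 is expected to stay at the limit as well, and the step from compound 1 to compound 4 is estimated as a step that the limit leaves unreadable from compound 1 to compound 4. Compound 4 is thus estimated at 150000 nM, with a range from 50000 nM to 500000 nM.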

Compound 4, concentration lethal to 50% of the cells: > 100000 nM
Compound 4: only a limit was reported; the forecaster's own chance of this, stated with the estimate: 80%; the middle value lies beyond the limit too.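

The result for compound 4 is again only a limit of the assay, > 100000 nM. With compound 1 also held at a limit, no step from compound 1 to compound 4 can be read: the limit of > 100000 nM in this assay, at which 4 of the 4 values shown sit.

The compounds shown leave open whether any change on the shared core moves the read-out away from that limit.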